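Enantiomer of compound 2 in the whole-organism rice assay

This account rests on a few compounds, and the source may have more. Where it says the series, first, only, none or still open, it means among the compounds named here.

Working notes on a small urea series. Compound 1 `C[C@H](NC(=O)Nc1ccccc1F)c1ccccc1` and compound 2 `C[C@@H](NC(=O)Nc1c(F)cccc1F)c1ccccc1` have both been measured in an ADME assay on the whole organism with Oryza sativa as the target, tested at 0.1 uM; a lower number here means a stronger effect, a higher number a weaker effect of the compound at the concentration tested. In this assay compound 1 gives 98%, and compound 2 gives 100%. The two numbers differ only within the usual scatter of the assay, so nothing separates compound 1 from compound 2 on the numbers seen so far; both sit at the top of the scale that this read-out allows.

The next compound, compound 3 `C[C@H](NC(=O)Nc1c(F)cccc1F)c1ccccc1`, has not yet been measured. Its relation to compound 2 is the two compounds have the same atoms and bonds and differ only in configuration as drawn: 1 of 1 stereo elements differ; a stereocentre at a saturated chain carbon is drawn R in compound 2 and S in compound 3. Among the compounds with values here, no step between two measured compounds of this kind, differing only in configuration, is available, so the size of such a step in this assay is unknown here.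

With both measured compounds near the upper end of the scale and the gap between them within the scatter, the change from compound 2 to compound 3 is expected to be a number 3 percentage points lower from compound 2 to compound 3 (within the scatter), no more than the scatter. Compound 3 is therefore expected to give about 97% in this assay, within a range from 85% to 100%.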

Compound 3, a percentage reported as activity, at one concentration (the size of the read-out at that concentration, not a potency): 100%
Compound 3: the middle estimate sits 3 percentage points below what was measured; the range from low to high includes it.
By their numbers in this assay, from the lowest: compounds 1, 2 and 3 (each within the scatter of the next).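

Within the data shown here, changing the stereocentre at the saturated chain carbon from R to S gives no change at the digits printed from compound 2 to compound 3 (within the scatter) in this assay, so at the concentration tested this change of configuration does not register in the read-out, and this is the only pair that reads such a change on its own: the fact that compounds 2 and 3 differ only in the configuration as drawn. Fluoro in place of hydrogen on an aromatic carbon, read with the configuration drawn as in compound 1, gives a number 2 percentage points higher from compound 1 to compound 3 (within the scatter), so this change also stays inside the usual scatter. Neither change at these two places moves the read-out away from the top of its scale, and the two steps together give no sign yet of which place matters in this assay.

On these data alone, with all three compounds at that end of the scale, it remains open whether configuration would matter in a compound whose read-out has room to move. Also open, as far as these compounds go, is what a different kind of group on that aromatic carbon, such as an amine or a carboxylic acid, would do to the read-out.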